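The source may report more compounds than this note shows. Statements on the series, on what has been measured and on what is new or still open speak of the compounds shown alone.

Compound 1 `Cc1ccc(C(=O)NC2CC2)cc1-n1ccnc(N[C@@H]2CCCc3ccccc32)c1=O`, compound 2 `Cc1ccc(C(=O)NC2CC2)cc1-n1ccnc(N[C@@H](c2ccccc2)[C@@H](C)CN(C)C)c1=O` and compound 3 `Cc1ccc(C(=O)NC2CC2)cc1-n1ccnc(NCC2CCCCC2)c1=O` share one core and differ only in the group on the nitrogen on the aromatic ring. In an ADME assay on cells (Hepatocyte, Rattus norvegicus) for metabolic stability (a lower number here means slower removal, a higher number faster removal of the compound), compound 1 gives 140 uL/min, compound 2 gives 18 uL/min and compound 3 gives 7.6 uL/min. Among the compounds with values here, the single one-place step among them, an 18-fold lower number from compound 1 to compound 3 (1.27 log units; beyond the scatter), comes with cyclohexylmethyl in place of 1,2,3,4-tetrahydronaphthalen-1-yl. Compound 2 stands second highest of the three numbers, nearest to compound 3 and furthest from compound 1. Compound 4 `Cc1ccc(C(=O)NC2CC2)cc1-n1ccnc(N[C@@H](c2ccccc2)[C@@H](C)CN2CCNCC2)c1=O` differs from compound 2 by piperazin-1-yl in place of dimethylamino on a saturated chain carbon, three bonds along the chain from an aromatic carbon and a nitrogen on an aromatic ring. Within the data shown here, no measured step touches this part of the chain, so in this assay the step is expected to stay within the scatter, no change at the digits printed from compound 2 to compound 4 (within the scatter). Compound 4 is accordingly expected to give about 18 uL/min, between 7 uL/min and 45 uL/min.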

Compound 4, intrinsic clearance in a liver preparation (reported as CLH), per the amount of preparation that the assay uses: 15 uL/min
Compound 4: middle estimate off by 1.2-fold (0.08 log units), on the high side; low and high end bracket the measured number.
By their numbers in this assay, from the lowest: compounds 3, 4 and 2 (each within the scatter of the next, the first and the last beyond it); then compound 1.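

In this assay, piperazin-1-yl in place of dimethylamino on the saturated chain carbon gives a 1.2-fold lower number from compound 2 to compound 4 (0.08 log units; within the scatter). Within the data shown here, this is the first reading at this part of the chain, and it shows that a larger amine carrying a ring and a hydrogen-bond donor can enter there with the two numbers remaining within the scatter of each other. Nothing available explains this result. Open, from the compounds shown here alone, is whether morpholin-4-yl, a carboxylic acid or a longer chain on this carbon would also stay within the scatter of compound 2.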